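Swapping the acyl group on the shared core

The source may hold more compounds than are shown below. What is called first, only, known or untested is meant among the compounds shown, and "the series" means these compounds.

Compound 1 `Fc1cccc(C#Cc2nc3c(s2)CN(C2CCC2)CC3)c1` reaches in an assay on HEK293 cells for positive allosteric modulation of metabotropic glutamate receptor 5 (Homo sapiens), read by FLIPR, with a stated time of 1 h (a higher number here means that more compound is needed for the effect, a lower number that less compound is needed), only the assay limit > 10000 nM. Compound 2 `O=C(C1CC12CCC2)N1CCc2nc(C#Cc3ccccc3)sc2C1` gives 3.9 nM. Compound 3 `COC1CC(C(=O)N2CCc3nc(C#Cc4ccccc4)sc3C2)C1` gives 640 nM.

Among the two actual numbers, compound 3 stands highest; its nearest neighbour is compound 2, and the step of a 160-fold higher number from compound 2 to compound 3 (2.22 log units; beyond the scatter) is large. Compound 4 `O=C(N1CCCCC1)N1CCc2nc(C#Cc3ccccc3)sc2C1` differs from compound 3 by piperidin-1-yl in place of 3-methoxycyclobutyl on a carbonyl carbon. Within the data shown here, no measured step places a piperidin-1-yl on this carbonyl carbon, so the only guidance is that the group on the carbonyl carbon can move the number strongly, as a 160-fold higher number from compound 2 to compound 3 (2.22 log units; beyond the scatter) shows, while compound 1 sits at the limit of > 10000 nM in this assay, at which 1 of the 3 values shown sits. Compound 4 is therefore expected to fall between compound 2 and compound 3, estimated at 100 nM with a range of 10 nM to 2000 nM. That expectation corresponds to a step of a 6.4-fold lower number from compound 3 to compound 4 (0.81 log units; beyond the scatter).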

Compound 4, half-maximal effective concentration: 75 nM
Compound 4: the middle estimate sits 1.3-fold (0.12 log units) above what was measured, and the stated range covers the measured number.
By their numbers in this assay, from the lowest: compound 2; then compound 4; then compound 3. At a limit, above all of these: compound 1.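

In this assay, piperidin-1-yl on the carbonyl carbon gives a clearly lower number than 3-methoxycyclobutyl, with an 8.5-fold lower number from compound 3 to compound 4 (0.93 log units; beyond the scatter). It still does not match the group of compound 2, with a 19-fold higher number from compound 2 to compound 4 (1.28 log units; beyond the scatter). The new value leaves the one limit in the set, which belongs to compound 1, standing alone: the limit of > 10000 nM in this assay, at which 1 of the 4 values shown sits.

On these data alone, what stays open is whether the lower number belongs to piperidin-1-yl specifically. Pyrrolidin-1-yl, morpholin-4-yl or dimethylamino on the same carbonyl carbon would test that.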